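The source may hold more compounds than are shown below. What is called first, only, known or untested is meant among the compounds shown, and "the series" means these compounds.

The series read so far in a functional assay on OVCAR-4 cells (Homo sapiens) for inhibition, read by sulforhodamine B assay, with a stated time of 48 h (a lower number here means a stronger inhibitor of growth, a higher number a weaker inhibitor of growth), holds three compounds. Compound 1 (`CN(C)/C=C/C(=O)c1nn(-c2ccccc2)c(-c2ccccc2)c1C#N`) stands at 63800 nM and compound 2 (`N#Cc1c(-c2nnc(O)c3nn(-c4ccccc4)cc23)nn(-c2ccccc2)c1-c1ccccc1`) at 26400 nM on the same scale. Compound 3 (`N#Cc1c(-c2nnc(-c3nn(-c4ccccc4)c(-c4ccccc4)c3C#N)c3nn(-c4ccccc4)cc23)nn(-c2ccccc2)c1-c1ccccc1`) gives 7460 nM as the lowest of the three numbers, and its gaps to compound 2 and compound 1 both lie beyond the usual scatter.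

Compound 4 (`N#Cc1c(-c2nnc(-c3nn(-c4ccccc4)c(-c4ccccc4)c3C#N)c3nn(-c4ccc(Cl)cc4)cc23)nn(-c2ccccc2)c1-c1ccccc1`) differs from compound 3 in one place: chloro in place of hydrogen on an aromatic carbon, or phenyl to 4-chlorophenyl (chloro in place of hydrogen on an aromatic carbon). Within the data shown here, no measured pair differs in one place only, so this step has no direct precedent here, and the three values give no trend for this kind of substitution. The expectation in this assay is a small step, none beyond the scatter, with a slight lean toward a lower number that remains a judgement and is not shown by the data. It starts from compound 3 at 7460 nM as the only close reference. The estimate amounts to a step (a 1.2-fold lower number from compound 3 to compound 4 (0.09 log units; within the scatter)) expected to stay within the scatter. Compound 4 is expected at 6000 nM within an estimated range of 2500 nM to 14000 nM on that scale.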

Compound 4, concentration for 50% growth inhibition: 43800 nM
Estimate against measurement, compound 4: 7.3-fold (0.86 log units) below; the measured number lies above the stated range.
By their numbers in this assay, from the lowest: compound 3; then compounds 2, 4 and 1 (each within the scatter of the next, the first and the last beyond it).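

In this assay, among these compounds, the change from phenyl to 4-chlorophenyl, with chloro in place of hydrogen on an aromatic carbon para to a large group, gives a 5.9-fold higher number from compound 3 to compound 4 (0.77 log units; beyond the scatter) and provides the first comparison between compounds that differ in one place. This position is therefore sensitive to substitution: a single chlorine atom is enough to produce a step beyond the scatter, and the direction is towards weaker inhibition of growth, leaving the unsubstituted phenyl of compound 3 as the better of this pair. No measurement bearing on the origin of this step is available, so the pair fixes its size and direction but offers no explanation.

With only one substituent shown at this position, it remains open whether the higher number is particular to chloro or would also appear with fluoro, methyl, methoxy, an amine or a carboxylic acid in its place. As far as these compounds go, it is equally open whether chloro on one of the other phenyl rings of compound 3 would give a step of similar size and direction, or whether the sensitivity is confined to this ring.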